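Removing one methoxy from compound 2 in the series

This account rests on a few compounds, and the source may have more. Where it says the series, first, only, none or still open, it means among the compounds named here.

Two compounds in this series carry measured numbers. Compound 1 `COc1ccc(-c2cc(/C=C/C(=O)c3cc(OC)c(OC)c(OC)c3)nc3cc(-c4ccccc4)nn23)cc1OC` gives 4700 nM in a functional assay on MDA-MB-231 cells (Homo sapiens) for antiproliferative activity, read by MTT assay, with a stated time of 24 h; a lower number here means a stronger inhibitor, a higher number a weaker inhibitor. Compound 2 `COc1cc(/C=C/C(=O)c2cc(-c3cc(OC)c(OC)c(OC)c3)n3nc(-c4ccccc4)cc3n2)cc(OC)c1OC` gives 18400 nM in this assay, the highest of the two numbers; its nearest neighbour is compound 1, and the gap between them lies beyond the usual scatter. Compound 3 `COc1ccc(-c2cc(C(=O)/C=C/c3cc(OC)c(OC)c(OC)c3)nc3cc(-c4ccccc4)nn23)cc1OC` is not yet measured. Its difference from compound 2 is hydrogen in place of methoxy on an aromatic carbon. Going by the values given here, no step between measured compounds with this same change exists here, so the expected size of the step rests on compound 2 and compound 1 alone. Compound 3 shares its 3,4-dimethoxyphenyl group with compound 1, whose number 4700 nM is the lower of the two, and so the step from compound 2 is expected to run toward a lower number, of the size a 2.3-fold lower number from compound 2 to compound 3 (0.36 log units; beyond the scatter). Compound 3 is therefore estimated at 8000 nM, with a range from 2500 nM to 25000 nM.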

Compound 3, half-maximal inhibitory concentration: 16700 nM
For compound 3 the middle estimate is 2.1-fold (0.32 log units) below the measured one; the measured number falls inside the stated range.
By their numbers in this assay, from the lowest: compound 1; then compounds 3 and 2 (each within the scatter of the next).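

In this assay, going by these compounds alone, the cut from 3,4,5-trimethoxyphenyl to 3,4-dimethoxyphenyl reads as a 1.1-fold lower number from compound 2 to compound 3 (0.04 log units; within the scatter), the first reading of this change. At this place, ortho to a methoxy group and meta to a large group, a methoxy and a hydrogen therefore cannot be told apart by this read-out, although this holds for this single pair only. No supporting measurement bears on the reason for this result.

On these data alone, whether a hydroxyl, a fluorine or an amine at this same place would give a step beyond the scatter remains open. Also open, as far as these compounds go, is whether hydrogen in place of methoxy reads the same way at the other methoxy groups of this ring or on another compound of the series.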